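Methoxy count on the benzoate ester and cytotoxicity

The source may report more compounds than this note shows. Statements on the series, on what has been measured and on what is new or still open speak of the compounds shown alone.

Among the measured compounds shown here, compound 3 `COC(=O)/C(=C\c1ccc(OC(=O)c2ccc(OC)cc2OC)cc1)Sc1ccnc2cc(Cl)ccc12` gives 7640 nM in a functional assay on HL-60 cells (Homo sapiens) for cytotoxicity, read by MTT assay, with a stated time of 24 h (a higher number here means a weaker inhibitor, a lower number a stronger inhibitor), the lowest of the three numbers so far. Compound 2 `COC(=O)/C(=C\c1ccc(OC(=O)c2cc(OC)cc(OC)c2)cc1)Sc1ccnc2cc(Cl)ccc12` gives 19000 nM and compound 1 `COC(=O)/C(=C\c1ccc(OC(=O)c2ccccc2OC)cc1)Sc1ccnc2cc(Cl)ccc12` gives 44500 nM. Compound 4 `COC(=O)/C(=C\c1ccc(OC(=O)c2cc(OC)c(OC)cc2OC)cc1)Sc1ccnc2cc(Cl)ccc12` differs from compound 3 by methoxy in place of hydrogen on an aromatic carbon. For the measured compounds named here, the closest precedent is a 5.8-fold lower number from compound 1 to compound 3 (0.77 log units; beyond the scatter), likewise a methoxy in place of hydrogen, while a 2.3-fold lower number from compound 1 to compound 2 (0.37 log units; beyond the scatter) and a 2.5-fold lower number from compound 2 to compound 3 (0.40 log units; beyond the scatter) show the number moving with the methoxy pattern in every measured step. A further lowering is therefore expected for compound 4, though smaller than a 5.8-fold lower number from compound 1 to compound 3 (0.77 log units; beyond the scatter), since a 2.5-fold lower number from compound 2 to compound 3 (0.40 log units; beyond the scatter) was already the smaller of the two steps into compound 3. Compound 4 is estimated at 5000 nM, with a range from 2000 nM to 15000 nM, an expected step of a 1.5-fold lower number from compound 3 to compound 4 (0.18 log units; within the scatter).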

Compound 4, half-maximal inhibitory concentration: 6260 nM
Estimate against measurement, compound 4: 1.3-fold (0.10 log units) below, within the range that was stated.
By their numbers in this assay, from the lowest: compounds 4 and 3 (each within the scatter of the next); then compound 2; then compound 1.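

In this assay, going from 2,4-dimethoxyphenyl to 2,4,5-trimethoxyphenyl gives a 1.2-fold lower number from compound 3 to compound 4 (0.09 log units; within the scatter), so this methoxy, para to a methoxy group, separates nothing, whereas the same kind of change gave a 5.8-fold lower number from compound 1 to compound 3 (0.77 log units; beyond the scatter). Methoxy in place of hydrogen therefore does not carry the same weight at every aromatic carbon of this ring. Compound 4 keeps the distance of compound 3 from the weaker compounds, with a 3.0-fold lower number from compound 2 to compound 4 (0.48 log units; beyond the scatter) and a 7.1-fold lower number from compound 1 to compound 4 (0.85 log units; beyond the scatter).

No evidence bears on this result. As far as these compounds go, whether an amine or a carboxylic acid at this position would move the number stays open.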